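The compounds below may be only part of what the source reports. "The series", "measured", "known", "first", "only" and "open" are said of these compounds alone.

Compounds measured in an assay on a cell-free system (plasma) for antagonist activity at proteinase-activated receptor 4 (Homo sapiens), with a stated time of 5 min, in the presence of a further agent that is not named here; on this read-out higher numbers stand for weaker inhibition and lower numbers for stronger inhibition:
- compound 1 `COc1cc(OCc2ccccc2OC)c2cc(-c3cn4nc(OC)sc4n3)oc2c1`: > 1000 nM
- compound 2 `COc1cc(OCc2ccccc2OCc2ccccc2)c2cc(-c3cn4nc(OC)sc4n3)oc2c1`: 2500 nM
- compound 3 `COc1cc(OCc2cccc(CCc3ccccc3)c2)c2cc(-c3cn4nc(OC)sc4n3)oc2c1`: 1200 nM

Compound 1 gives only a limit in this assay, (the limit of > 1000 nM in this assay, at which 1 of the 3 values shown sits), not a number. For that reason the step that the limit leaves unreadable from compound 1 to compound 2 cannot be sized. For the measured compounds named here, compound 3, with 1200 nM, holds the lower of the two numbers, and the gap to compound 2 at 2500 nM lies beyond the scatter; no step between these two compounds is drawn, so only the two values themselves are available.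

Compound 4 `COc1cc(OCc2cccc(Oc3ccccc3)c2)c2cc(-c3cn4nc(OC)sc4n3)oc2c1` differs from compound 3 by phenoxy in place of phenethyl on an aromatic carbon. Going by the values given here, none of the measured steps concerns this kind of change, and the one step that is drawn is unreadable, so there is nothing to point in either direction. Compound 3 and compound 2 together suggest that the group at this position moves the number only modestly, and compound 4 is therefore expected to sit near compound 3, the step of a 1.3-fold higher number from compound 3 to compound 4 (0.10 log units; within the scatter) being estimated as within the scatter. The estimate for compound 4 in this assay is 1500 nM, with a range from 600 nM to 4000 nM.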

Compound 4, half-maximal inhibitory concentration: 390 nM
For compound 4 the middle estimate is 3.8-fold (0.59 log units) above the measured one, and the stated range ends above it.
By their numbers in this assay, from the lowest: compound 4; then compound 3; then compound 2.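

In this assay, for the compounds shown here, phenoxy in place of phenethyl on an aromatic carbon, meta to a large group, gives the first readable step at this position: a 3.1-fold lower number from compound 3 to compound 4 (0.49 log units; beyond the scatter). The change therefore moves the number beyond the scatter, even though both groups carry one six-membered aromatic ring of carbon only; as counted, phenoxy enters with 1 oxygen and 1 hydrogen-bond acceptor, while phenethyl leaves with 0 hydrogen-bond acceptors. The compounds shown offer no measurement that accounts for this step.

On these data alone, how an anilino group or a longer chain such as benzyloxy would read in place of phenoxy remains open. Also open, as far as these compounds go, is whether the same change would give a step of similar size on a different core.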